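Cytotoxicity on the shared core: a longer aryl ether

The source may report more compounds than this note shows. Statements on the series, on what has been measured and on what is new or still open speak of the compounds shown alone.

Compound 1 `COc1ccc(C(O)C2OC(=O)c3c(OC)cc(OC)cc32)cc1`: in an ADME assay on RAW264.7 cells (Mus musculus) for cytotoxicity, read by MTT assay, with a stated time of 24 h, in the absence of a further agent (on this read-out higher numbers stand for weaker inhibition and lower numbers for stronger inhibition), compound 1 gives > 40000 nM, a limit of the assay.
Compound 2 `CCC(C)Oc1ccc(C(O)C2OC(=O)c3c(OC)cc(OC)cc32)cc1`: in this assay compound 2 gives > 40000 nM, a limit of the assay.
Compound 3 `COCCCOc1ccc(C(O)C2OC(=O)c3c(OC)cc(OC)cc32)cc1`: in this assay compound 3 gives > 40000 nM, a limit of the assay.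

Compound 1 stands at the limit of > 40000 nM in this assay, at which 3 of the 3 values shown sit; no number places it against the others. The steps a step that the two limits leave unreadable from compound 1 to compound 2 and a step that the two limits leave unreadable from compound 1 to compound 3 are both unreadable, as is a step that the two limits leave unreadable from compound 2 to compound 3, so changing the group on the oxygen on the aromatic ring has given no readable movement.

Compound 4 `COc1cc(OC)c2c(c1)C(C(O)c1ccc(OCCOc3ccccc3)cc1)OC2=O` differs from compound 1 by phenoxymethyl in place of hydrogen on a saturated chain carbon bound to an oxygen on an aromatic ring. The steps from compound 1 to compound 2 and to compound 3 bear on this change; neither could be read, so no step beyond the scatter is expected. The expected step is a number no higher from compound 1 to compound 4 (the limit leaves the size open). Compound 4 is therefore estimated at 40000 nM, within 20000 nM to 100000 nM, most likely again only a limit.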

Compound 4, half-maximal inhibitory concentration: > 40000 nM
Compound 4 ended at the assay's limit; the forecaster's own chance of this, stated with the estimate: 80%; the middle value lies on the limit itself.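

The steps from compound 1, compound 2 and compound 3 to compound 4 cannot be read, as each joins two limits: the limit of > 40000 nM in this assay, at which 4 of the 4 values shown sit.

Whether any group on the oxygen on the aromatic ring moves the read-out in this assay stays open, with no compound shown giving a number.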